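The source may hold more compounds than are shown below. What is called first, only, known or untested is meant among the compounds shown, and "the series" means these compounds.

Measured compounds in a functional assay on MCF7 cells (Homo sapiens) for inhibition, read by MTT assay, with a stated time of 72 h; on this read-out higher numbers stand for weaker inhibition and lower numbers for stronger inhibition:
compound 1 `CC(C)n1ncc2c(C(=O)NCc3cn(-c4ccccc4)nn3)cccc21` — > 40000 nM
compound 2 `CC(C)n1ncc2c(C(=O)NCc3cn(Cc4ccccc4)nn3)cccc21` — 9170 nM

Compound 1 sits at a limit of this assay, (the limit of > 40000 nM in this assay, at which 1 of the 2 values shown sits), so no number is known for it. Compound 2 gives 9170 nM. Among the measured compounds shown here, the one measured step at this position is an at least 4.3-fold lower number from compound 1 to compound 2 (0.63 log units; beyond the scatter). Compound 3 `CC(C)n1ncc2c(C(=O)NCc3cn(Cc4ccc(C#N)cc4)nn3)cccc21` differs from compound 1 by 4-cyanobenzyl in place of phenyl on an aromatic nitrogen. The measured benzyl step bears on it directly, and nothing measured speaks to the nitrile. For compound 3 a step of an at least 4.4-fold lower number from compound 1 to compound 3 (0.64 log units; beyond the scatter) toward stronger inhibition is expected, of about the size seen for compound 2. Compound 3 is estimated at 9000 nM, within 3000 nM to 30000 nM.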

Compound 3, half-maximal inhibitory concentration: > 40000 nM
Compound 3: no number, only a limit; the forecaster's own chance of this, stated with the estimate: 15%; middle value at least 4.4-fold (0.64 log units) from the limit.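

In this assay, cyano in place of hydrogen on an aromatic carbon gives an at least 4.3-fold higher number from compound 2 to compound 3 (0.63 log units; beyond the scatter), so the benefit of the benzyl step does not carry over to 4-cyanobenzyl. Compound 3 stands at a limit, not a number: the limit of > 40000 nM in this assay, at which 2 of the 3 values shown sit. The step from compound 1 to compound 3 cannot be read, since both values are limits.

As far as these compounds go, it remains open whether this loss is specific to the nitrile or would also follow from a fluorine, a methoxy group or an amine at the same carbon. From the compounds shown here alone, the effect of a longer chain in place of benzyl also remains open.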